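The source may hold more compounds than are shown below. What is called first, only, known or untested is meant among the compounds shown, and "the series" means these compounds.

In an ADME assay on liver for metabolic stability, with Liver microsome (Homo sapiens) as the target, read by LC-MS, using microsomes (on this read-out lower numbers stand for slow clearance and higher numbers for fast clearance), compound 1 `O=C(NCc1cc(Cl)ccc1-n1cnnn1)[C@@H]1CC=NN1C(=O)[C@H](O)c1ccccc1F` gives 16 mL.min-1.g-1. Compound 2 `O=C(NCc1cc(Cl)ccc1-n1cnnn1)[C@@H]1CC=NN1C(=O)[C@H](O)Cc1ccccc1` gives < 12 mL.min-1.g-1, which is a limit of the assay and not a number. For the measured compounds named here, the only measured step is an at least 1.3-fold lower number from compound 1 to compound 2 (0.12 log units; that floor lies within the scatter), and it brought benzyl in place of 2-fluorophenyl. Compound 3 `CC(C)CC[C@@H](O)C(=O)N1N=CC[C@H]1C(=O)NCc1cc(Cl)ccc1-n1cnnn1` has not yet been measured. It carries isobutyl in place of phenyl on a saturated chain carbon, two bonds along the chain from a carbonyl carbon and an oxygen on a saturated carbon, and the same difference can be read as benzyl to isopentyl: isobutyl in place of phenyl on a saturated chain carbon, two bonds along the chain from a carbonyl carbon and an oxygen on a saturated carbon. The measured step bears on this change only loosely, since compound 1 and compound 2 both keep an aromatic ring and compound 3 has none. Going by the values given here, with an at least 1.3-fold lower number from compound 1 to compound 2 (0.12 log units; that floor lies within the scatter) as the sole guide, no large move is expected, only a small rise that need not stand clear of the usual scatter. The estimated step is an at least 1.0-fold higher number from compound 2 to compound 3 (0.03 log units; that floor lies within the scatter). Compound 3 is estimated at 13 mL.min-1.g-1 in this assay, with an expected range from 6 mL.min-1.g-1 to 28 mL.min-1.g-1.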

Compound 3, intrinsic clearance in microsomes: 47 mL.min-1.g-1
Beside the measured number, compound 3's estimate is 3.6-fold (0.56 log units) below it; the measured number lies above the stated range.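

In this assay, compound 1 and compound 2 both keep an aromatic ring at this position, so neither could show what happens when the ring is gone, and compound 3 now does. With isobutyl in place of phenyl, the read-out shows an at least 3.9-fold higher number from compound 2 to compound 3 (0.59 log units; beyond the scatter), and with isopentyl in place of 2-fluorophenyl it shows a 2.9-fold higher number from compound 1 to compound 3 (0.47 log units; beyond the scatter), so both compounds with an aromatic ring stand clear of compound 3 on the slow-clearance side, and what sits at this position matters for clearance in this assay. The true size of the step from the phenyl compound may be larger than its floor, since compound 2 is recorded as a limit of the assay and not a number: the limit of < 12 mL.min-1.g-1 in this assay, at which 1 of the 3 values shown sits.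

The compounds shown cannot tell whether losing the ring itself or some other difference between the groups goes with the higher number, as phenyl and isobutyl differ in more than the ring alone. From the compounds shown here alone, a cyclohexyl group would keep a six-membered ring without aromaticity, and a chain ending in an amine or a carboxylic acid would test another kind of group, so how either would read here remains open.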